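A Smaller Amine Tail on the Shared Core

The source may report more compounds than this note shows. Statements on the series, on what has been measured and on what is new or still open speak of the compounds shown alone.

Compound 1 `COc1ccc(/C=C\c2cc(OC)c(OC)c(OC)c2)cc1OCc1ccc(CN2CC(C(=O)O)C2)cc1`: > 10000 nM
Compound 2 `COc1ccc(/C=C\c2cc(OC)c(OC)c(OC)c2)cc1OCc1ccc(CN2CC[C@H](O)C2)cc1`: 7200 nM
Compound 3 `COc1ccc(/C=C\c2cc(OC)c(OC)c(OC)c2)cc1OCc1ccc(CN2CCCCC2C(=O)NCCN)cc1`: > 10000 nM

These three compounds were tested in a functional assay on MC-38 cells (Mus musculus) for antiproliferative activity, read by CCK-8 assay, with a stated time of 48 h; on this read-out higher numbers stand for weaker inhibition and lower numbers for stronger inhibition. For compound 1 the value is a limit of the assay, not a number, and the same holds for compound 3. Compound 3 therefore stands at the weak end of what is shown, as in the limit of > 10000 nM in this assay, at which 2 of the 3 values shown sit, so its exact potency is unknown. Among the compounds with values here, two measured steps touch compound 3: an at least 1.3-fold higher number from compound 2 to compound 3 (0.14 log units; that floor lies within the scatter), and a step that the two limits leave unreadable from compound 1 to compound 3. Only compound 2, carrying the smallest tail with a hydroxyl, gives an actual number.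

Compound 4 `COc1ccc(/C=C\c2cc(OC)c(OC)c(OC)c2)cc1OCc1ccc(CNCCO)cc1` differs from compound 3 by (2-hydroxyethyl)amino in place of 2-((2-aminoethyl)carbamoyl)piperidin-1-yl on a saturated chain carbon bound to an aromatic carbon. The large tail leaves and a short hydroxylated amine enters, which brings compound 4 closer in size to compound 2. A change toward compound 2 is therefore expected. The step expected here is an estimated at least 1.2-fold lower number from compound 3 to compound 4 (0.09 log units; that floor lies within the scatter). A result at the limit remains quite possible. Compound 4 is estimated at 8000 nM, with a range from 3000 nM to 20000 nM.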

Compound 4, half-maximal inhibitory concentration: 1200 nM
Beside the measured number, compound 4's estimate is 6.7-fold (0.82 log units) above it; the measured number lies below the stated range.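

In this assay, the saturated chain carbon bound to an aromatic carbon can carry a tail that gives clearer inhibition than any earlier compound: exchanging 3-hydroxypyrrolidin-1-yl for the open (2-hydroxyethyl)amino group gives a 6.0-fold lower number from compound 2 to compound 4 (0.78 log units; beyond the scatter). The same group also replaces the two other tails, with an at least 8.3-fold lower number from compound 3 to compound 4 (0.92 log units; beyond the scatter) and an at least 8.3-fold lower number from compound 1 to compound 4 (0.92 log units; beyond the scatter). Those two steps are floors rather than exact sizes, because compound 1 and compound 3 each stand at a limit of the assay: the limit of > 10000 nM in this assay, at which 2 of the 4 values shown sit.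

On these data alone, what a plain ethylamino group or a longer 3-hydroxypropylamino chain would give on this carbon remains open. The compounds shown therefore cannot tell whether the hydroxyl or the length of the chain matters more.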